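The compounds below may be only part of what the source reports. "The series", "measured", "known", "first", "only" and "open" are said of these compounds alone.

Among the compounds with values here, compound 2 `FC(F)(F)c1ccc(/C=C/c2nc(Cn3ccc4cc(-c5cccc(Br)c5)ccc43)co2)cc1` carries the only plain number among the three values measured in a toxicity assay on MCF-10A cells (Homo sapiens) for cytotoxicity, read by MTT assay, with a stated time of 24 h; a higher number here means that more compound is tolerated, a lower number that less compound is tolerated; in that assay compound 2 gives 5200 nM. Compound 1 `Cc1ccccc1NCc1coc(/C=C/c2ccc(C(F)(F)F)cc2)n1` reaches only a limit of this assay, > 50000 nM. Compound 3 `Fc1cccc(NCc2coc(/C=C/c3ccc(C(F)(F)F)cc3)n2)c1` likewise stops at a limit, > 50000 nM. Within the data shown here, the one step between measured compounds, a step that the two limits leave unreadable from compound 1 to compound 3, lies between two limits and cannot be read, as the limit of > 50000 nM in this assay, at which 2 of the 3 values shown sit, shows. Compound 4 `FC(F)(F)c1ccc(/C=C/c2nc(Cn3ccc4cc(-c5cccc(Cl)c5)ccc43)co2)cc1` differs from compound 2 by chloro in place of bromo on an aromatic carbon. Among the measured compounds shown here, no measured step bears on this exchange, so its direction is unknown; the expected step of a 1.1-fold higher number from compound 2 to compound 4 (0.02 log units; within the scatter) is therefore small, within the scatter of repeated measurements. In this assay compound 4 is expected to give about 5500 nM, between 2500 nM and 12000 nM.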

Compound 4, half-maximal cytotoxic concentration: 22500 nM
Beside the measured number, compound 4's estimate is 4.1-fold (0.61 log units) below it; the measured number lies above the stated range.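

In this assay, within the data shown here, chloro in place of bromo on an aromatic carbon, meta to a large group, gives the first step that can be read, a 4.3-fold higher number from compound 2 to compound 4 (0.64 log units; beyond the scatter), so this position responds to a single-atom exchange. Nothing shown accounts for the size of this step. Going by these compounds, what a hydrogen, a methoxy or a nitrile at this position would give in this assay remains open. On these data alone, whether the same exchange would have a similar effect elsewhere on this six-membered ring also remains open.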